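The compounds below may be only part of what the source reports. "The series", "measured", "known", "first", "only" and "open" are said of these compounds alone.

Measured compounds in this study:
Compound 1 `CCC[C@@H](CCO)Nc1nc(N)nc(C)c1Cc1ccc(CN2CCCC2)cc1OC` – 501 nM
Compound 2 `CCC[C@@H](CCO)Nc1nc(N)nc(C)c1Cc1ccc(CN2CCN(C)CC2)cc1OC` – 631 nM

In an assay on HEK-Blue hTLR8 cells for agonist activity at Toll-like receptor 8 (Homo sapiens), with a stated time of 20 h (on this read-out lower numbers stand for an effect already at smaller amounts and higher numbers for an effect only at larger amounts of compound), compound 1 gives 501 nM. Within the data shown here, the only other measured compound, compound 2, gives 631 nM, and the step of a 1.3-fold higher number from compound 1 to compound 2 (0.10 log units; within the scatter) is within the scatter, so the two numbers cannot be told apart on this read-out. Compound 1 thus stands at one end of a pair that is, in effect, a single level.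

Compound 3 `CCC[C@@H](CO)Nc1nc(N)nc(C)c1Cc1ccc(CN2CCCC2)cc1OC` shortens the side chain on the exocyclic nitrogen of the shared core: hydroxy in place of hydroxymethyl on a saturated chain carbon, two bonds along the chain from a nitrogen on an aromatic ring. Among the measured compounds shown here, no measured step bears on this change. For the measured compounds named here, the single step available, a 1.3-fold higher number from compound 1 to compound 2 (0.10 log units; within the scatter), concerns the substituent at the other end of the molecule and is itself within the scatter; it offers no guidance on the hydroxyalkyl chain. With nothing to point either way, the step from compound 1 to compound 3 is expected to be a 1.2-fold higher number from compound 1 to compound 3 (0.08 log units; within the scatter), that is, no change beyond the scatter, with a wide allowance for the unknown. Compound 3 is therefore estimated at 600 nM in this assay, within a range of 250 nM to 1500 nM.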

Compound 3, half-maximal effective concentration: 63.1 nM
Estimate against measurement, compound 3: 9.5-fold (0.98 log units) above; the measured number lies below the stated range.
By their numbers in this assay, from the lowest: compound 3; then compounds 1 and 2 (each within the scatter of the next).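

In this assay, the side chain proves sensitive to a small change: with 1-(hydroxymethyl)butyl in place of 1-(2-hydroxyethyl)butyl on the exocyclic nitrogen of the shared core, the read-out shows a 7.9-fold lower number from compound 1 to compound 3 (0.90 log units; beyond the scatter). Among these compounds, the earlier exchange of pyrrolidin-1-yl for 4-methylpiperazin-1-yl gave only a 1.3-fold higher number from compound 1 to compound 2 (0.10 log units; within the scatter), so this is the first change to move the number beyond the scatter, and it does so through the loss of a single carbon counted under the hydroxyalkyl groups. Nothing available here accounts for the size of this step.

The compounds shown leave open whether the same exchange of hydroxyalkyl chains would give a step of similar size when 4-methylpiperazin-1-yl replaces pyrrolidin-1-yl, since only the pyrrolidin-1-yl pair can be read. They also leave open how the number would respond at this place to a group other than hydroxy on the chain, such as an amine or a carboxylic acid, or to a change in the propyl chain on the same saturated carbon, such as a longer chain.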